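Benzyl for Cyclopentylmethyl on the Ring Amine

This account rests on a few compounds, and the source may have more. Where it says the series, first, only, none or still open, it means among the compounds named here.

The series shares a core that differs only in the group on a saturated chain carbon bound to an amine nitrogen in a ring. Compound 1 `COc1cc(N)c(Cl)cc1NC(=O)C1CCN(CC2CC2)CC1` carries cyclopropyl there. In a functional assay on the whole organism for antagonist activity, with Mus musculus as the target (on this read-out lower numbers stand for an effect already at smaller amounts and higher numbers for an effect only at larger amounts of compound), compound 1 gives a limit of the assay, > 10 mg/kg. Compound 2 `COc1cc(N)c(Cl)cc1NC(=O)C1CCN(CC2CCCC2)CC1` carries cyclopentyl. In this assay compound 2 also gives only a limit, > 10 mg/kg. Compound 3 `COc1cc(N)c(Cl)cc1NC(=O)C1CCN(Cc2ccc(O)cc2)CC1` carries 4-hydroxyphenyl. In this assay compound 3 gives a limit as well, > 8 mg/kg. Because two of the three values sit at the limit of > 10 mg/kg in this assay, at which 2 of the 3 values shown sit, and the third at the limit of > 8 mg/kg in this assay, at which 1 of the 3 values shown sits, the steps a step that the two limits leave unreadable from compound 1 to compound 2, a step that the two limits leave unreadable from compound 1 to compound 3 and a step that the two limits leave unreadable from compound 2 to compound 3 are all unreadable. Compound 4 `COc1cc(N)c(Cl)cc1NC(=O)C1CCN(Cc2ccccc2)CC1` is the unmeasured member; its change from compound 2 is phenyl in place of cyclopentyl on a saturated chain carbon bound to an amine nitrogen in a ring. The nearest measured step, compound 2 to compound 3, also involves an aromatic ring and is unreadable, so no size or direction of step can be expected beyond the scatter. Compound 4 is therefore estimated at 12 mg/kg, with a range from 4 mg/kg to 40 mg/kg, and the step that the limit leaves unreadable from compound 2 to compound 4 is expected most likely to end in another limit.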

Compound 4, dose for half-maximal effect: 0.5 mg/kg
Estimate against measurement, compound 4: 24-fold (1.38 log units) above; the whole stated range lies above it.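

At this position, phenyl in place of cyclopentyl gives an at least 20-fold lower number from compound 2 to compound 4 (1.30 log units; beyond the scatter), and phenyl in place of cyclopropyl gives an at least 20-fold lower number from compound 1 to compound 4 (1.30 log units; beyond the scatter), both minimum sizes because compound 1 and compound 2 each stand at a limit: the limit of > 10 mg/kg in this assay, at which 2 of the 4 values shown sit.

An aromatic ring there does not decide the outcome alone, as hydrogen in place of hydroxy on an aromatic carbon gives an at least 16-fold lower number from compound 3 to compound 4 (1.20 log units; beyond the scatter), a minimum size because compound 3 stands at a limit: the limit of > 8 mg/kg in this assay, at which 1 of the 4 values shown sits.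

Compound 4 is thus the only compound shown whose value in this assay is a number rather than a limit.

From the compounds shown here alone, the true sizes of these steps stay open, and the steps among compound 1, compound 2 and compound 3 remain unreadable. Also open, going by these compounds, is whether the effect would persist with a fluoro or methoxy group on the phenyl ring, or with a longer chain such as phenylethyl on the ring amine.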